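Compound 3 to compound 4: chloro gives way to trifluoromethyl

The source may report more compounds than this note shows. Statements on the series, on what has been measured and on what is new or still open speak of the compounds shown alone.

Compound 1 `N#CCCN(Cc1cccs1)S(=O)(=O)c1ccc(F)cc1`: > 205000 nM, a limit
Compound 2 `N#CCCN(Cc1cccs1)S(=O)(=O)c1ccc(Cl)cc1`: > 195000 nM, a limit
Compound 3 `N#CCCN(Cc1ccco1)S(=O)(=O)c1ccc(Cl)cc1`: > 205000 nM, a limit

In an ADME assay on MDCK cells (Canis lupus familiaris) for cytotoxicity, read by MTT assay, with a stated time of 24 h (on this read-out lower numbers stand for higher toxicity in this test and higher numbers for lower toxicity in this test), compound 3 stands only at a limit of > 205000 nM. That is the limit of > 205000 nM in this assay, at which 2 of the 3 values shown sit. Compound 4 `N#CCCN(Cc1ccco1)S(=O)(=O)c1ccc(C(F)(F)F)cc1` has trifluoromethyl in place of chloro on an aromatic carbon. For the measured compounds named here, two measured steps bear on this change: a step that the two limits leave unreadable from compound 1 to compound 2, a swap of one group for another on an aromatic carbon, and a step that the two limits leave unreadable from compound 2 to compound 3. Neither gives a size to carry over, so no step beyond the scatter is expected in this assay, in either direction, and another limit is the likely report. The estimated step is an at least 1.1-fold lower number from compound 3 to compound 4 (0.04 log units; that floor lies within the scatter). For compound 4 the expected value is 186000 nM, with an estimated range from 100000 nM to 320000 nM.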

Compound 4, half-maximal cytotoxic concentration: > 186000 nM
Compound 4 ended at the assay's limit; the forecaster's own chance of this, stated with the estimate: 80%; the middle value sits exactly at the limit.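

Compound 3 and compound 4 are both reported only as limits in this assay, so no step can be read between them. The compounds shown leave open whether trifluoromethyl in place of chloro changes the read-out at all.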